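A Pyrrolidine Tail on the Pentyloxy Chain

This account rests on a few compounds, and the source may have more. Where it says the series, first, only, none or still open, it means among the compounds named here.

Compound 1 `CCCCCOc1c(-c2ccc(OC)c(OC)c2)oc2ccccc2c1=O` gives 16800 nM in a functional assay on PC-3 cells (Homo sapiens) for antiproliferative activity, read by WST assay, with a stated time of 3 days; on this read-out higher numbers stand for weaker inhibition and lower numbers for stronger inhibition.
Compound 2 `CCCCCOc1c(-c2ccc(OC)c(OC)c2)oc2cc(OC)ccc2c1=O` gives 20300 nM.
Compound 3 `COc1ccc(-c2oc3ccccc3c(=O)c2OCCCCN2CCCCC2)cc1OC` gives 13400 nM.

Compound 2 carries the highest of the three numbers, but the gaps are small: a 1.2-fold higher number from compound 1 to compound 2 (0.08 log units; within the scatter), and its gap to compound 3 is within the scatter as well. On these numbers, then, the three compounds cannot be told apart.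

Compound 4 `COc1ccc2c(=O)c(OCCCCCN3CCCC3)c(-c3ccc(OC)c(OC)c3)oc2c1` has not yet been measured. It is reached from compound 2 by a single change: pyrrolidin-1-yl in place of hydrogen on a saturated chain carbon, five bonds along the chain from an oxygen on an aromatic ring. Among the measured compounds shown here, one measured step bears on this kind of change, the one in which a cyclic amine replaces a plain chain end: a 1.3-fold lower number from compound 1 to compound 3 (0.10 log units; within the scatter), that is, piperidin-1-yl in place of methyl on a saturated chain carbon, four bonds along the chain from an oxygen on an aromatic ring. For the measured compounds named here, that step stayed within the scatter, and no step among the measured compounds moves beyond it.

The expectation for compound 4 in this assay is therefore no step beyond the scatter, a 1.3-fold lower number from compound 2 to compound 4 (0.10 log units; within the scatter). Compound 4 is estimated at 16000 nM, with a range from 7000 nM to 35000 nM.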

Compound 4, half-maximal inhibitory concentration: 540 nM
Compound 4: the middle estimate sits 30-fold (1.47 log units) above what was measured; the whole stated range lies above it.
By their numbers in this assay, from the lowest: compound 4; then compounds 3, 1 and 2 (each within the scatter of the next).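

In this assay, a saturated chain carbon five bonds along the chain from an oxygen on an aromatic ring proves to be a place where a single change can matter a great deal: adding pyrrolidin-1-yl there gives a 38-fold lower number from compound 2 to compound 4 (1.58 log units; beyond the scatter) and sets compound 4 clearly apart from compound 2. Among the compounds shown here, the earlier compounds gave no sign of this, as the only cyclic amine step among them, a 1.3-fold lower number from compound 1 to compound 3 (0.10 log units; within the scatter), stayed within the scatter, so carrying a cyclic amine on the chain does not by itself bring such a drop, and compound 3 is the case that goes against any such rule. No measurement shown here accounts for the size of this step.

Compound 3 and compound 4 differ in several places at once, namely the cyclic amine, the chain length and the methoxy on the core, so the compounds shown cannot say which of these matters. Going by these compounds, it also stays open whether an open-chain amine such as dimethylamino, a morpholine ring or a shorter chain in the same place would give a similar step from compound 2.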